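Working notes on the aryl variation, compounds 1 to 4

This account rests on a few compounds, and the source may have more. Where it says the series, first, only, none or still open, it means among the compounds named here.

Measured compounds:
Compound 1 `O=C1Nc2ccc(Br)cc2/C1=N/NC(=S)N/N=C/c1ccc(-c2ccccc2)cc1` gives 3250 nM in a functional assay on HeLa cells (Homo sapiens) for inhibition, read by MTT assay; a higher number here means a weaker inhibitor, a lower number a stronger inhibitor.
Compound 2 `O=C1Nc2ccc(Br)cc2/C1=N/NC(=S)N/N=C/c1c(F)cccc1Cl` gives 1610 nM in this assay.
Compound 3 `O=C1Nc2ccc(Br)cc2/C1=N/NC(=S)N/N=C/c1ccccc1Br` gives only a limit of the assay, > 50000 nM, in this assay.

Compound 3 thus stands at the edge of what the assay reports: its value is a limit and not a number, and it sits at the limit of > 50000 nM in this assay, at which 1 of the 3 values shown sits. Compound 1 and compound 2 both give numbers well inside the measurable range.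

Compound 4 `COc1ccc(/C=N/NC(=S)N/N=C2\C(=O)Nc3ccc(Br)cc32)cc1O` is not yet measured. It differs from compound 3 by 3-hydroxy-4-methoxyphenyl in place of 2-bromophenyl on a carbon with a double bond to nitrogen.

For the measured compounds named here, only one measured step bears on a change of this aryl group: an at least 31-fold higher number from compound 2 to compound 3 (1.49 log units; beyond the scatter). That step shows that swapping the aryl group can move the number very far, and that the 2-bromophenyl of compound 3 sits at the weak end. Since compound 3 is a limit, the step to compound 4 can only go towards a lower number or stay at the limit. A return towards the numbers of compound 1 and compound 2 is expected, so compound 4 is estimated at 6000 nM, between 1500 nM and 50000 nM, which means an expected step of an at least 8.3-fold lower number from compound 3 to compound 4 (0.92 log units; beyond the scatter).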

Compound 4, half-maximal inhibitory concentration: 2220 nM
For compound 4 the middle estimate is 2.7-fold (0.43 log units) above the measured one, and the stated range covers the measured number.
By their numbers in this assay, from the lowest: compounds 2, 4 and 1 (each within the scatter of the next, the first and the last beyond it). At a limit, above all of these: compound 3.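

In this assay, 3-hydroxy-4-methoxyphenyl in place of 2-bromophenyl gives an at least 22-fold lower number from compound 3 to compound 4 (1.35 log units; beyond the scatter), so this position on a carbon with a double bond to nitrogen also accepts an aryl group carrying a hydroxy and a methoxy group, without the loss seen for compound 3. With a 1.4-fold higher number from compound 2 to compound 4 (0.14 log units; within the scatter), 3-hydroxy-4-methoxyphenyl and 2-chloro-6-fluorophenyl cannot be told apart in this assay, although the two groups have no substituent in common. Among the compounds shown, the loss at this position is so far tied only to the 2-bromophenyl of compound 3, whose value is a limit and not a number: the limit of > 50000 nM in this assay, at which 1 of the 4 values shown sits.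

The compounds shown do not separate the hydroxy group of compound 4 from its methoxy group, so it stays open whether either one contributes to the value on its own. Also open, from the compounds shown here alone, is how the number responds when the aryl group carries an amine or a carboxylic acid, and whether a single chlorine on the ring behaves like the 2-bromophenyl of compound 3 or like the 2-chloro-6-fluorophenyl of compound 2.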